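The compounds below may be only part of what the source reports. "The series", "measured", "known", "first", "only" and "open" are said of these compounds alone.

Compound 3 `Cc1ccc(Nc2nc(SCc3cn(CC(=O)NC(=O)Nc4ccccn4)nn3)nc(-c3ccc(Cl)cc3)c2C#N)cc1` carries a chloro group on the aromatic ring attached to the shared core, and in a functional assay on B16-F10 cells (Mus musculus) for inhibition, read by MTT assay, with a stated time of 72 h (a higher number here means a weaker inhibitor, a lower number a stronger inhibitor), compound 3 gives 1320 nM. Among the three measured compounds this is the second highest number: compound 1 `Cc1ccc(Nc2nc(SCc3cn(CC(=O)NC(=O)Nc4ccccn4)nn3)nc(-c3ccc(C(C)C)cc3)c2C#N)cc1`, which carries isopropyl at the same position, gives 3060 nM, and compound 2 `Cc1ccc(Nc2nc(SCc3cn(CC(=O)NC(=O)Nc4ccccn4)nn3)nc(-c3ccc(C)cc3)c2C#N)cc1`, which carries methyl there, gives 1010 nM.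

Compound 4 `Cc1ccc(Nc2nc(SCc3cn(CC(=O)NC(=O)Nc4ccccn4)nn3)nc(-c3ccccc3)c2C#N)cc1` differs from compound 3 by hydrogen in place of chloro on an aromatic carbon. The measured steps that bear on this change all concern the same position. There was a 3.0-fold lower number from compound 1 to compound 2 (0.48 log units; beyond the scatter) and a 2.3-fold lower number from compound 1 to compound 3 (0.37 log units; beyond the scatter), so trimming the isopropyl to a smaller group lowered the number. Between the two small groups, however, there was a 1.3-fold higher number from compound 2 to compound 3 (0.12 log units; within the scatter), which is a difference too small to count. Removing the chloro group entirely continues in the direction of smaller groups, so the expectation is a step of a 1.3-fold lower number from compound 3 to compound 4 (0.12 log units; within the scatter), small and possibly within the scatter, with the number tending slightly lower rather than higher.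

Compound 4 is therefore estimated at 1000 nM in this assay, within a range from 400 nM to 2500 nM.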

Compound 4, half-maximal inhibitory concentration: 3300 nM
Compound 4: the middle estimate sits 3.3-fold (0.52 log units) below what was measured; measured number outside the range, above it.
By their numbers in this assay, from the lowest: compounds 2 and 3 (each within the scatter of the next); then compounds 1 and 4 (each within the scatter of the next).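

Removing the chloro group does not leave the number unchanged or slightly lower: in this assay there is a 2.5-fold higher number from compound 3 to compound 4 (0.40 log units; beyond the scatter), and the comparison with the methyl analogue gives a 3.3-fold higher number from compound 2 to compound 4 (0.51 log units; beyond the scatter). The unsubstituted phenyl compound instead falls level with the isopropyl compound, with a 1.1-fold higher number from compound 1 to compound 4 (0.03 log units; within the scatter), so this position does not follow a simple rule in which a shorter group gives a lower number: among these four compounds, methyl and chloro give the lower numbers, while hydrogen and isopropyl give the higher ones. Nothing shown here explains this pattern.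

On these data alone, it remains open whether fluoro, methoxy or ethyl at this place on the ring would give numbers like those of methyl and chloro or like those of hydrogen and isopropyl. As far as these compounds go, it is also open whether an amine or a carboxylic acid here would fit either pair, and whether the same pattern would appear with changes elsewhere on the shared core.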